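A few compounds are considered here, and "the series" means these few. Any claim that something is new, unique, unknown or untested is made for them only; others in the source may bear on it.

Compound 1 `COc1cc(-c2cc(/C=C/C(=O)c3ccc(N)cc3)[nH]n2)cc(OC)c1OC` and compound 2 `COc1ccc(-c2cc(/C=C/C(=O)c3ccc(N)cc3)[nH]n2)cc1OC` share one core and differ at a single aromatic carbon. In a functional assay on RXF 393 cells (Homo sapiens) for cytotoxicity, read by sulforhodamine B assay, with a stated time of 48 h, tested at 1 uM (a higher number here means a weaker effect of the compound at the concentration tested, a lower number a stronger effect), compound 1 gives 67%, and compound 2 gives 94%. The change between them is hydrogen in place of methoxy on an aromatic carbon and it made the step of a number 27 percentage points higher from compound 1 to compound 2 (beyond the scatter).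

Compound 3 `COc1cc(C(=O)/C=C/c2cc(-c3cc(OC)c(OC)c(OC)c3)n[nH]2)cc(OC)c1OC` stands on a different core; how that core differs from the core of compound 1 is not broken down here. In this assay compound 3 gives 65%. Compound 3 and compound 1 lie within the scatter of each other, while compound 2 lies beyond the scatter above both of them.

Compound 4 `COc1ccc(-c2cc(/C=C/C(=O)c3cc(OC)c(OC)c(OC)c3)[nH]n2)cc1OC` has not yet been measured. It differs from compound 3 by hydrogen in place of methoxy on an aromatic carbon. The place lines of the two changes agree word for word, so this is the same change as the one from compound 1 to compound 2, and it occurs twice among the compounds shown.

For the measured compounds named here, a step of similar size is expected here because the only measured instance of this change gave a number 27 percentage points higher from compound 1 to compound 2 (beyond the scatter). The step expected in this assay is therefore a number 25 percentage points higher from compound 3 to compound 4 (beyond the scatter), and it rests on compound 1 and compound 2 alone. For compound 4 the expected number in this assay is 90%, with a range estimated from 75% to 100%.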

Compound 4, a percentage reported as activity, at one concentration (the size of the read-out at that concentration, not a potency): 80%
Compound 4: the middle estimate sits 10 percentage points above what was measured; measured number inside the range.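

Replacing methoxy with hydrogen on the aromatic carbon gives a number 15 percentage points higher from compound 3 to compound 4 (beyond the scatter) in this assay, the same direction as a number 27 percentage points higher from compound 1 to compound 2 (beyond the scatter), so on both cores the compound carrying hydrogen shows the weaker effect at the concentration tested. The two steps do not differ beyond what two such steps can scatter, so the change carries from the core of compound 1 to the core of compound 3 in direction and, as far as this read-out can tell, in size: the same change on two cores in this assay, a number 27 percentage points higher (beyond the scatter) from compound 1 to compound 2 and a number 15 percentage points higher (beyond the scatter) from compound 3 to compound 4, 12 percentage points apart, within the scatter of two such steps. This rests on just two pairs at one place in the molecule, so it does not show that the step would hold on any further core, and it gives no reason for the loss of effect or any measure of potency.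

The compounds shown have only methoxy or hydrogen at this place, which leaves open whether a hydroxy group, a chlorine atom or a longer chain such as ethoxy would keep the effect seen with methoxy. Also open, going by these compounds, is whether the same step appears in other cell lines, since every number here comes from one read-out at a single concentration.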